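The source may report more compounds than this note shows. Statements on the series, on what has been measured and on what is new or still open speak of the compounds shown alone.

Compound 1 `Cc1ccc(NC(=O)N2CCN(c3nccc(Oc4cc(Cl)cc(Cl)c4)n3)CC2)cc1` gives 11600 nM in a functional assay on MDA-MB-231 cells (Homo sapiens) for antiproliferative activity, read by MTT assay, with a stated time of 24 h; a lower number here means a stronger inhibitor, a higher number a weaker inhibitor
Compound 2 `O=C(Nc1cccc(Cl)c1)N1CCN(c2nccc(Oc3cc(Cl)cc(Cl)c3)n2)CC1` gives 7900 nM in this assay

Only these two values are known so far, and they lie within the usual scatter of each other, so compound 2 stands level with compound 1. The next compound, compound 3 `O=C(Nc1ccccc1Cl)N1CCN(c2nccc(Oc3cc(Cl)cc(Cl)c3)n2)CC1`, differs from compound 2 as follows: 2-chlorophenyl in place of 3-chlorophenyl on an amide-type nitrogen. The two have the same atoms, joined differently, with 2-chlorophenyl in place of 3-chlorophenyl on an amide-type nitrogen. Within the data shown here, one measured step bears on this, a 1.5-fold lower number from compound 1 to compound 2 (0.17 log units; within the scatter), which also changed the group on that nitrogen and stayed within the scatter. Among the measured compounds shown here, no measured compound carries 2-chlorophenyl, so that single step is only a weak guide, and no clear move in either direction is expected in this assay. The expected step is a 1.1-fold higher number from compound 2 to compound 3 (0.06 log units; within the scatter) and would lie within the scatter. Compound 3 is estimated at about 9000 nM, with an expected range from 4500 nM to 18000 nM.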

Compound 3, half-maximal inhibitory concentration: 11000 nM
Estimate against measurement, compound 3: 1.2-fold (0.09 log units) below, within the range that was stated.
By their numbers in this assay, from the lowest: compounds 2, 3 and 1 (each within the scatter of the next).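

In this assay, exchanging 3-chlorophenyl for 2-chlorophenyl on the amide-type nitrogen gives a 1.4-fold higher number from compound 2 to compound 3 (0.14 log units; within the scatter), so these two chlorophenyl isomers cannot be told apart at this position. Exchanging 4-methylphenyl for 2-chlorophenyl on the same nitrogen gives a 1.1-fold lower number from compound 1 to compound 3 (0.02 log units; within the scatter), so all three groups shown there stand level, with no pair separated by more than the scatter. Nothing measured here offers a reason for this result.

The compounds shown leave open whether a group of a different kind on this nitrogen, such as a cyclohexyl ring, a benzyl group or a phenyl ring carrying a carboxylic acid, would move the number beyond the scatter. They also leave open whether a change elsewhere in the shared core, which all three compounds carry unaltered, would matter more than any change at this position.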